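Compound 4: pent-1-en-1-yl in place of ethynyl

This account rests on a few compounds, and the source may have more. Where it says the series, first, only, none or still open, it means among the compounds named here.

Compound 1 `CCCCC(=O)N(Cc1ccc(OC)c(O)c1)c1cc(OC)c(OC)c(OC)c1`: 300 nM
Compound 2 `COc1ccc(CN(C(C)=O)c2cc(OC)c(OC)c(OC)c2)cc1O`: 160 nM
Compound 3 `C#CC(=O)N(Cc1ccc(OC)c(O)c1)c1cc(OC)c(OC)c(OC)c1`: 570 nM

In a functional assay on KYSE-450 cells (Homo sapiens) for inhibition, read by MTT assay, with a stated time of 48 h (a higher number here means a weaker inhibitor, a lower number a stronger inhibitor), compound 3 stands within the scatter of one neighbour, with a 1.9-fold higher number from compound 1 to compound 3 (0.28 log units; within the scatter), but apart from the other, with a 3.6-fold higher number from compound 2 to compound 3 (0.55 log units; beyond the scatter). Compound 4 `CCC/C=C/C(=O)N(Cc1ccc(OC)c(O)c1)c1cc(OC)c(OC)c(OC)c1` has pent-1-en-1-yl in place of ethynyl on a carbonyl carbon. Two measured steps replace ethynyl at this place. Within the data shown here, compound 1 carries butyl, the nearer chain by length, and its step stays within the scatter, while the methyl of compound 2 gives the only modest step. A small move toward a lower number is therefore expected, namely a 1.9-fold lower number from compound 3 to compound 4 (0.28 log units; within the scatter). The estimated value for compound 4 is 300 nM, with an expected range of 120 nM to 750 nM.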

Compound 4, half-maximal inhibitory concentration: 57 nM
For compound 4 the middle estimate is 5.3-fold (0.72 log units) above the measured one; the measured number lies below the stated range.
By their numbers in this assay, from the lowest: compound 4; then compounds 2, 1 and 3 (each within the scatter of the next, the first and the last beyond it).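

In this assay, pent-1-en-1-yl on the carbonyl carbon gives a 10-fold lower number from compound 3 to compound 4 (1.00 log units; beyond the scatter), and it also goes beyond both saturated groups, with a 5.3-fold lower number from compound 1 to compound 4 (0.72 log units; beyond the scatter) and a 2.8-fold lower number from compound 2 to compound 4 (0.45 log units; beyond the scatter). Among these compounds, the earlier compounds showed no separation between butyl and methyl at this place, so this is the first sign that a chain with a double bond can lower the number here. No measurement at hand explains this gain. Going by these compounds, whether it follows from the double bond or from the chain length remains open. A pentyl chain and a prop-1-en-1-yl group would separate the two.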